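The compounds below may be only part of what the source reports. "The series", "measured", "known", "first", "only" and "open" are said of these compounds alone.

Measured compounds in a functional assay, tested at 50 ug/mL; on this read-out lower numbers stand for a weaker effect and higher numbers for a stronger effect at the one concentration tested:
- compound 1, `N#CC1=C(N)OC(c2c[nH]c3ccccc23)=C(C#N)C1c1ccc(Br)cc1`: 14.2%
- compound 2, `CN(C)c1ccc(C2C(C#N)=C(N)OC(c3c[nH]c4ccccc34)=C2C#N)cc1`: 14.4%
- compound 3, `Cc1ccc(C2C(C#N)=C(N)OC(c3c[nH]c4ccccc34)=C2C#N)cc1`: 5.2%

Compound 2 gives the highest of the three numbers in this assay, but this carries no order: the step of a number 0.2 percentage points higher from compound 1 to compound 2 (within the scatter) and the step of a number 9.2 percentage points lower from compound 2 to compound 3 (within the scatter) both lie within the scatter, as does a number 9 percentage points lower from compound 1 to compound 3 (within the scatter). The three measured compounds therefore read as one level, with swaps of bromo, dimethylamino and methyl on an aromatic carbon leaving the read-out unmoved.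

Compound 4, `N#CC1=C(N)OC(c2c[nH]c3ccccc23)=C(C#N)C1c1cccc2ccccc12`, has not been measured. Relative to compound 2 the change is naphthalen-1-yl in place of 4-(dimethylamino)phenyl on a saturated ring carbon. Among the compounds with values here, no measured step exchanges this whole ring for another; the three steps available only vary a substituent on it, and each was within the scatter. They give no basis for expecting a move in either direction in this assay, so the working expectation is a step no larger than the scatter, a number 1.4 percentage points lower from compound 2 to compound 4 (within the scatter), with a wide range to cover the untested kind of change. Compound 4 is thus estimated at 13%, between 3% and 27%.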

Compound 4, a percentage reported as activity, at one concentration (the size of the read-out at that concentration, not a potency): 4.7%
Compound 4: the middle estimate sits 8.3 percentage points above what was measured; low and high end bracket the measured number.
By their numbers in this assay, from the lowest: compounds 4, 3, 1 and 2 (each within the scatter of the next).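

In this assay, exchanging the whole ring on the saturated ring carbon, and not only a substituent on it, still gives no readable step: naphthalen-1-yl yields a number 9.7 percentage points lower from compound 2 to compound 4 (within the scatter), a number 9.5 percentage points lower from compound 1 to compound 4 (within the scatter) and a number 0.5 percentage points lower from compound 3 to compound 4 (within the scatter). All four compounds therefore read as one level, so at this position neither the substituents on the phenyl ring nor the change from one six-membered aromatic ring to two separates the compounds. No measurement available here explains this flat reading.

Still open, from the compounds shown here alone, is whether any group at this position can move the read-out beyond the scatter, since all four compounds carry an aromatic carbon ring there. A carboxylic acid on the phenyl ring, or a saturated amine such as piperidin-4-yl in place of that ring, would test this.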